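Methoxyphenyl in place of methylphenyl on the amide nitrogen

The compounds below may be only part of what the source reports. "The series", "measured", "known", "first", "only" and "open" are said of these compounds alone.

Compound 1 `Cc1ccccc1NC(=O)Nc1cccc(CNc2ncnc3ccccc23)c1`: in a functional assay on MGC-803 cells (Homo sapiens) for antiproliferative activity, read by MTT assay (on this read-out lower numbers stand for stronger inhibition and higher numbers for weaker inhibition), compound 1 gives > 50000 nM, a limit of the assay.
Compound 2 `COc1cc2ncnc(NCc3cccc(NC(=O)Nc4ccccc4C)c3)c2cc1OC`: compound 2 gives > 50000 nM, again a limit.
Compound 3 `COc1cc2ncnc(NCc3cccc(NC(=O)Nc4cccc(C)c4)c3)c2cc1OC`: compound 3 gives 44600 nM.

Among the measured compounds shown here, compound 3 thus holds the only number among the three results; the other two sit at a limit (the limit of > 50000 nM in this assay, at which 2 of the 3 values shown sit). For the measured compounds named here, the single measured step, an at least 1.1-fold lower number from compound 2 to compound 3 (0.04 log units; that floor lies within the scatter), lies within the scatter. Compound 4 `COc1ccc(NC(=O)Nc2cccc(CNc3ncnc4cc(OC)c(OC)cc34)c2)cc1` differs from compound 3 by 4-methoxyphenyl in place of 3-methylphenyl on an amide-type nitrogen. Going by the values given here, no measured step involves a methoxyphenyl group, so nothing bears directly on this change, and the one step that exists was small. Compound 4 is therefore expected to show no step beyond the scatter, a 1.1-fold higher number from compound 3 to compound 4 (0.05 log units; within the scatter), with a fair chance that the assay again returns only a limit. Compound 4 is estimated at 50000 nM, between 20000 nM and 150000 nM.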

Compound 4, half-maximal inhibitory concentration: 12300 nM
Beside the measured number, compound 4's estimate is 4.1-fold (0.61 log units) above it; the whole stated range lies above it.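

In this assay, the group on the amide-type nitrogen proved able to move the result beyond the scatter, which the earlier step had not shown: the change to 4-methoxyphenyl gives a 3.6-fold lower number from compound 3 to compound 4 (0.56 log units; beyond the scatter). Against 2-methylphenyl, whose compound stands only at a limit, the same group gives an at least 4.0-fold lower number from compound 2 to compound 4 (0.60 log units; beyond the scatter), which is a floor and not a measured size. Limits still mark part of this series: the limit of > 50000 nM in this assay, at which 2 of the 4 values shown sit.

The step from 3-methylphenyl to 4-methoxyphenyl changes the group and its place in one move, so the two contributions cannot be told apart. As far as these compounds go, how a chlorophenyl or a plain phenyl group on that nitrogen would read stays open.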